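Moving the trifluoromethyl group around the phenyl ring

The source may report more compounds than this note shows. Statements on the series, on what has been measured and on what is new or still open speak of the compounds shown alone.

Compound 2 `Oc1cccc(-c2cc(-c3cccc(C(F)(F)F)c3)cc(-c3cccc(O)c3)n2)c1` is measured in a functional assay on HeLa cells (Homo sapiens) for inhibition (a higher number here means a weaker inhibitor, a lower number a stronger inhibitor), and gives 12700 nM. Its closest relative, compound 1 `Oc1cccc(-c2cc(-c3ccccc3F)cc(-c3cccc(O)c3)n2)c1`, gives 16000 nM in this assay, and the two values lie within the scatter of each other. The step from compound 1 to compound 2 a 1.3-fold lower number from compound 1 to compound 2 (0.10 log units; within the scatter) is the only one measured so far. Compound 3 `Oc1cccc(-c2cc(-c3ccc(C(F)(F)F)cc3)cc(-c3cccc(O)c3)n2)c1` differs from compound 2 by 4-(trifluoromethyl)phenyl in place of 3-(trifluoromethyl)phenyl on an aromatic carbon. Among the compounds with values here, no measured step moves a group around a ring, so the only guide is that the one swap seen left the number unchanged; compound 3 is therefore expected to show a 1.1-fold lower number from compound 2 to compound 3 (0.02 log units; within the scatter), with an estimated value of 12000 nM, between 5000 nM and 30000 nM.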

Compound 3, half-maximal inhibitory concentration: > 50000 nM
Compound 3 was reported as a limit (the forecaster's own chance of this, stated with the estimate: 10%); middle value at least 4.1-fold (0.61 log units) from the limit.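

Swapping 3-(trifluoromethyl)phenyl for 4-(trifluoromethyl)phenyl keeps the same atoms yet gives an at least 3.9-fold higher number from compound 2 to compound 3 (0.59 log units; beyond the scatter), so at this place, opposite the ring nitrogen, the position of the group on the phenyl ring matters, which the earlier step could not show. Replacing 2-fluorophenyl with 4-(trifluoromethyl)phenyl likewise gives an at least 3.1-fold higher number from compound 1 to compound 3 (0.49 log units; beyond the scatter). In this assay compound 3 gives > 50000 nM, which is a limit and not a number.

From the compounds shown here alone, how far compound 3 lies past that limit remains open. So does whether an amine or a carboxylic acid in place of the trifluoromethyl group would follow the same trend.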